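Shortening the ether chain: from compound 2 to compound 3

The compounds below may be only part of what the source reports. "The series", "measured", "known", "first", "only" and "open" are said of these compounds alone.

Measured so far:
compound 1 `C=CCc1cc(OC)c(OC(C)C(OCCOCCCC)c2ccc(O)c(OC)c2)c(OC)c1` — 153 nM
compound 2 `C=CCc1cc(OC)c(OC(C)C(OCCCCCCCCCC)c2ccc(O)c(OC)c2)c(OC)c1` — 66 nM

In an assay on HEK293 cells for agonist activity at transient receptor potential cation channel subfamily M member 8 (Homo sapiens), read by fluorescence and calcium flux, with a stated time of 5 min (a higher number here means that more compound is needed for the effect, a lower number that less compound is needed), compound 2 gives 66 nM, the lowest of the two numbers. Compound 1 gives 153 nM, and the step of a 2.3-fold lower number from compound 1 to compound 2 (0.37 log units; beyond the scatter) lies beyond the scatter. Compound 3 `C=CCc1cc(OC)c(OC(C)C(OC(C)C)c2ccc(O)c(OC)c2)c(OC)c1` differs from compound 2 by isopropyl in place of decyl on an oxygen on a saturated carbon. Among the compounds with values here, the one step that bears on this, a 2.3-fold lower number from compound 1 to compound 2 (0.37 log units; beyond the scatter), went with a longer chain; here the chain becomes much shorter, so a higher number is expected, likely a modest step, a 3.0-fold higher number from compound 2 to compound 3 (0.48 log units; beyond the scatter). Compound 3 is estimated at 200 nM, with a range of 80 nM to 600 nM.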

Compound 3, half-maximal effective concentration: 82 nM
The estimate for compound 3 lay 2.4-fold (0.39 log units) above the measured number; measured number inside the range.
By their numbers in this assay, from the lowest: compounds 2, 3 and 1 (each within the scatter of the next, the first and the last beyond it).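

In this assay this oxygen carries isopropyl as well as decyl, with a 1.2-fold higher number from compound 2 to compound 3 (0.09 log units; within the scatter) showing that the long chain is not needed for a number close to that of compound 2. Set against 2-butoxyethyl, isopropyl gives a 1.9-fold lower number from compound 1 to compound 3 (0.27 log units; within the scatter) and so no reading of order, which means that a simple link between chain length and the number does not hold across these compounds. No measurement here accounts for this. Open, from the compounds shown here alone, is whether ethyl, a cyclohexyl ring, or an amine or a carboxylic acid at the end of the chain would keep such numbers.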